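Benzyl to 4-Bromophenyl: A Step Expected to Stay Flat

The compounds below may be only part of what the source reports. "The series", "measured", "known", "first", "only" and "open" are said of these compounds alone.

Compound 1 `O=C1NC(=O)/C(=C/c2ccc(OCCSc3nnc(Cc4ccccc4)[nH]3)cc2)S1`: 22.8%
Compound 2 `Cc1ccc(-c2nnc(SCCOc3ccc(/C=C4\SC(=O)NC4=O)cc3)[nH]2)cc1`: 21.7%
Compound 3 `O=C1NC(=O)/C(=C/c2ccc(OCCSc3nnc(-c4ccc(Cl)cc4)[nH]3)cc2)S1`: 24.6%

All three were measured in a functional assay on the whole organism (strain Wistar) with Rattus norvegicus as the target, with a stated time of 15 days, at a dose of 10 mg/kg by the oral route; a higher number here means a stronger effect of the compound at the dose given, a lower number a weaker effect. Compound 1 stands second highest of the three numbers, with its neighbours close on either side: a number 1.1 percentage points lower from compound 1 to compound 2 (within the scatter), and a number 1.8 percentage points higher from compound 1 to compound 3 (within the scatter). The remaining pair is equally close: a number 2.9 percentage points higher from compound 2 to compound 3 (within the scatter). Among the compounds with values here, no step among the three reaches beyond the scatter, so the numbers are best read as one level rather than an order.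

Compound 4 `O=C1NC(=O)/C(=C/c2ccc(OCCSc3nnc(-c4ccc(Br)cc4)[nH]3)cc2)S1` has not yet been measured. It differs from compound 1 in one place.

4-bromophenyl in place of benzyl on an aromatic carbon

Within the data shown here, the steps that bear on this change are the two that likewise replace benzyl on that aromatic carbon with a substituted phenyl, a number 1.1 percentage points lower from compound 1 to compound 2 (within the scatter) with 4-methylphenyl and a number 1.8 percentage points higher from compound 1 to compound 3 (within the scatter) with 4-chlorophenyl. Both stayed within the scatter, and the swap of chloro for methyl, a number 2.9 percentage points higher from compound 2 to compound 3 (within the scatter), added nothing beyond it either. Compound 4 is therefore expected to show no step beyond the scatter in this assay, in neither direction. For compound 4 the estimate is 24%, with a range from 14% to 34%. That estimate means an expected step of a number 1.2 percentage points higher from compound 1 to compound 4 (within the scatter).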

Compound 4, a percentage reported as activity, at one dose (the size of the read-out at that dose, not a potency): 26.9%
The estimate for compound 4 lay 2.9 percentage points below the measured number; the range from low to high includes it.
By their numbers in this assay, from the lowest: compounds 2, 1, 3 and 4 (each within the scatter of the next).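

In this assay, a third substituted phenyl on this aromatic carbon of the five-membered ring with 3 nitrogen leaves the picture flat: 4-bromophenyl in place of benzyl gives a number 4.1 percentage points higher from compound 1 to compound 4 (within the scatter), so this position has now taken methyl, chloro and bromo on the phenyl ring without any step from benzyl leaving the scatter. Changing only the group on that phenyl ring does not separate the compounds either, with bromo in place of chloro giving a number 2.3 percentage points higher from compound 3 to compound 4 (within the scatter) and bromo in place of methyl giving a number 5.2 percentage points higher from compound 2 to compound 4 (within the scatter), so the four compounds still read as one level rather than an order. Nothing available here offers an explanation for how closely these groups agree.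

Every group shown at this position carries a six-membered aromatic ring of carbon only, so it remains open whether the same level would hold with an amine, a carboxylic acid or a longer alkyl chain on this carbon. The read-out also comes from a single oral dose, which leaves open whether these compounds would separate at any other dose.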